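The compounds below may be only part of what the source reports. "The series", "measured", "known", "first", "only" and "open" are said of these compounds alone.

Working notes on the series in an ADME assay on L929 cells (Mus musculus) for cytotoxicity, read by resazurin assay, with a stated time of 72 h; a higher number here means a weaker inhibitor, a lower number a stronger inhibitor.

Compound 3 `CCCCCC(=O)c1ccn(-c2ccc3c(c2)B(O)OC3)c1` gives > 10 ug/mL in this assay, which is a limit of the assay and not a number. Compound 1 `O=C(c1ccn(-c2ccc3c(c2)B(O)OC3)c1)c1ccc(Cl)cc1Cl` likewise gives > 10 ug/mL, a limit. Compound 2 `O=C(c1ccccc1)c1ccn(-c2ccc3c(c2)B(O)OC3)c1` gives > 10 ug/mL, again a limit. Because all three sit at the limit of > 10 ug/mL in this assay, at which 3 of the 3 values shown sit, none of the steps among them can be read: the exchange of the 2,4-dichlorophenyl on the carbonyl carbon for phenyl gives a step that the two limits leave unreadable from compound 1 to compound 2, for pentyl gives a step that the two limits leave unreadable from compound 1 to compound 3, and the exchange of phenyl for pentyl gives a step that the two limits leave unreadable from compound 2 to compound 3. Compound 3 therefore stands where every measured compound stands, at the limit, and no size or direction of change within the three is visible.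

Compound 4 `NCCCC(=O)c1ccn(-c2ccc3c(c2)B(O)OC3)c1` differs from compound 3 by amino in place of ethyl on a saturated chain carbon, three bonds along the chain from a carbonyl carbon, so the pentyl chain on the carbonyl carbon becomes a 3-aminopropyl chain. For the measured compounds named here, no measured step bears on this change in this assay, since the three steps are all unreadable. With every measured value sitting at the limit, the expected step is a step that the limit leaves unreadable from compound 3 to compound 4, that is, none beyond the scatter that the data would let one see. Compound 4 is accordingly expected at 20 ug/mL, within 8 ug/mL to 60 ug/mL, most likely reported once more as a limit.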

Compound 4, half-maximal inhibitory concentration: > 10 ug/mL
Compound 4: a limit, no number (the forecaster's own chance of this, stated with the estimate: 85%); the middle value is on the limit's open side.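

In this assay compound 4 gives > 10 ug/mL, a limit of the assay and not a number. The steps to compound 4 from compound 1, compound 2 and compound 3 therefore cannot be read: the limit of > 10 ug/mL in this assay, at which 4 of the 4 values shown sit.

The compounds shown leave open whether any exchange of the group on the carbonyl carbon changes the result in this assay, and by how much.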